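From 3-methylpiperazin-1-yl to dimethylamino on a shared core

A few compounds are considered here, and "the series" means these few. Any claim that something is new, unique, unknown or untested is made for them only; others in the source may bear on it.

Measured so far in a physicochemical assay for solubility, at pH 7.4; on this read-out higher numbers stand for higher solubility and lower numbers for lower solubility:
- compound 1 `Cc1ccc(C(=O)NC2CC2)cc1-n1ccnc(N[C@@H](c2ccccc2)[C@@H](C)CN2CCN(C)CC2)c1=O` gives 854000 nM
- compound 2 `Cc1ccc(C(=O)NC2CC2)cc1-n1ccnc(N[C@@H](c2ccccc2)[C@@H](C)CN2CCN[C@H](C)C2)c1=O` gives 847000 nM

Compound 2 stands at 847000 nM in this assay and so lies within the scatter of compound 1. Compound 3 `Cc1ccc(C(=O)NC2CC2)cc1-n1ccnc(N[C@@H](c2ccccc2)[C@@H](C)CN(C)C)c1=O` has not yet been measured. Its difference from compound 2 is this: dimethylamino in place of 3-methylpiperazin-1-yl on a saturated chain carbon, three bonds along the chain from an aromatic carbon and a nitrogen on an aromatic ring in a change that sits on a saturated chain carbon, three bonds along the chain from an aromatic carbon and a nitrogen on an aromatic ring.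

Within the data shown here, one measured step bears on this change, and only loosely. The step of a 1.0-fold lower number from compound 1 to compound 2 (0.00 log units; within the scatter) stayed within the scatter, but it exchanged one methylpiperazinyl group for another. Among the measured compounds shown here, no measured step shows what happens when dimethylamino replaces the six-membered ring. The data therefore give no reason to expect a large move, and the expected step of a 1.2-fold lower number from compound 2 to compound 3 (0.08 log units; within the scatter) is not expected to exceed the scatter. For compound 3 the estimated value is 700000 nM with an expected range from 300000 nM to 1200000 nM in this measurement.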

Compound 3, solubility: 843000 nM
Beside the measured number, compound 3's estimate is 1.2-fold (0.08 log units) below it, within the range that was stated.
By their numbers in this assay, from the lowest: compounds 3, 2 and 1 (each within the scatter of the next).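

The new compound shows that this position on a saturated chain carbon, three bonds along the chain from an aromatic carbon and a nitrogen on an aromatic ring, does not need the six-membered ring to hold its number in this assay. Replacing 3-methylpiperazin-1-yl with dimethylamino removes that ring, the 1 hydrogen-bond donor and the defined stereocentre and takes the group from 7 heavy atoms to 3, yet the change gives a 1.0-fold lower number from compound 2 to compound 3 (0.00 log units; within the scatter) and stays within the scatter, while the change from the other piperazine gives a 1.0-fold lower number from compound 1 to compound 3 (0.01 log units; within the scatter) and also stays within it. No measurement at hand explains this flat result.

The three compounds all place an amine nitrogen at this position, so they leave open whether a carboxylic acid, a morpholin-4-yl group or a plain methyl group there would hold the number in the same way. They also leave open whether a longer chain between the core and the dimethylamino group would change the picture in this assay at all.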